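The source may hold more compounds than are shown below. What is called first, only, known or untested is meant among the compounds shown, and "the series" means these compounds.

Measured so far:
compound 1, `CC(C)[C@@H](N)C(=O)NCc1ccc(F)cc1`: 21 mg/kg
compound 2, `CC(C)[C@@H](N)C(=O)NCc1ccc(COc2cccc(F)c2)cc1`: < 30 mg/kg

In a functional assay on the whole organism (strain albino Sprague-Dawley) with Rattus norvegicus as the target, in the maximal electroshock model (a lower number here means that less compound is needed, a higher number that more compound is needed for the effect), compound 1 gives 21 mg/kg. For compound 2 this assay reports only a limit, < 30 mg/kg, so the standing of compound 2 is known no closer than that (the limit of < 30 mg/kg in this assay, at which 1 of the 2 values shown sits). Compound 3, `Cc1ccc(CNC(=O)[C@H](N)C(C)C)cc1`, has not been measured in this assay. It differs from compound 2 in one place: hydrogen in place of 3-fluorophenoxy on a saturated chain carbon bound to an aromatic carbon. Within the data shown here, no measured pair shares this change, so there is no measured step to lean on; both measured compounds sit in the same region, and the limit for compound 2 leaves open how far it reaches. The expectation is a step from compound 2 to compound 3 of a step that the limit leaves unreadable from compound 2 to compound 3, no larger than the usual scatter, in either direction. Compound 3 is expected to give 25 mg/kg in this assay, with a range from 10 mg/kg to 60 mg/kg.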

Compound 3, dose for half-maximal effect: 50 mg/kg
Beside the measured number, compound 3's estimate is 2.0-fold (0.30 log units) below it; the range from low to high includes it.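

In this assay, hydrogen in place of 3-fluorophenoxy on a saturated chain carbon bound to an aromatic carbon gives an at least 1.6-fold higher number from compound 2 to compound 3 (0.22 log units; that floor lies within the scatter), so the series keeps its effect with the larger group present and does not lose it on that group's removal. Among these compounds, the full size of this step cannot be read, because the value for compound 2 is a limit and not a number: the limit of < 30 mg/kg in this assay, at which 1 of the 3 values shown sits. Methyl in place of fluoro on an aromatic carbon gives a 2.4-fold higher number from compound 1 to compound 3 (0.38 log units; beyond the scatter), which is the first step to lie beyond the scatter, and it shows that this position responds to a small change.

Going by these compounds, whether chloro or methoxy at that aromatic carbon would fall closer to compound 1 or to compound 3 stays open. Also open, on these data alone, is how an unsubstituted phenoxy would compare with 3-fluorophenoxy on the saturated chain carbon.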